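Indanylamine returns with a methylene spacer on the piperidine

The compounds below may be only part of what the source reports. "The series", "measured", "known", "first", "only" and "open" are said of these compounds alone.

Three compounds share one core, differing only in the group on the amine nitrogen. In an assay on CHO cells for agonist activity at 5-hydroxytryptamine receptor 1D (Homo sapiens), read by GTPgammaS binding (on this read-out lower numbers stand for an effect already at smaller amounts and higher numbers for an effect only at larger amounts of compound), compound 1 `c1ccc2c(c1)CCC2NC1CCN(CCCc2c[nH]c3ccc(-n4cnnc4)cc23)CC1` gives 25 nM, compound 2 `c1cc(CNC2CCN(CCCc3c[nH]c4ccc(-n5cnnc5)cc34)CC2)co1` gives 7.1 nM, and compound 3 `OCCC(NC1CCN(CCCc2c[nH]c3ccc(-n4cnnc4)cc23)CC1)c1ccccc1` gives 5.1 nM. Compound 3 has the lowest of the three numbers; the step of a 4.9-fold lower number from compound 1 to compound 3 (0.69 log units; beyond the scatter) lies beyond the scatter, while a 1.4-fold lower number from compound 2 to compound 3 (0.14 log units; within the scatter) does not, and a 3.5-fold lower number from compound 1 to compound 2 (0.55 log units; beyond the scatter) is modest. Compound 4 `c1ccc2c(c1)CCC2NCC1CCN(CCCc2c[nH]c3ccc(-n4cnnc4)cc23)CC1` carries ((2,3-dihydro-1H-inden-1-yl)amino)methyl in place of (3-hydroxy-1-phenylpropyl)amino on a saturated ring carbon. The closest guide is compound 1, whose 25 nM shows the indanylamine giving the highest number of the set, so a higher number than compound 3 is expected, about a 3.9-fold higher number from compound 3 to compound 4 (0.59 log units; beyond the scatter). Compound 4 is therefore estimated at 20 nM, with a range from 6 nM to 70 nM.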

Compound 4, half-maximal effective concentration: 1.3 nM
Compound 4: middle estimate off by 15-fold (1.19 log units), on the high side; measured number below the stated range.
By their numbers in this assay, from the lowest: compound 4; then compounds 3 and 2 (each within the scatter of the next); then compound 1.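

In this assay the added methylene alone gives a 19-fold lower number from compound 1 to compound 4 (1.28 log units; beyond the scatter) and is a large step, so the indanylamine that gave the highest number in compound 1 is not unfavourable in every setting. Both a 5.5-fold lower number from compound 2 to compound 4 (0.74 log units; beyond the scatter) and a 3.9-fold lower number from compound 3 to compound 4 (0.59 log units; beyond the scatter) lie beyond the scatter, which places compound 4 lowest of the four. Nothing available here explains these steps.
Going by these compounds, it stays open whether (furan-3-yl)methyl or 3-hydroxy-1-phenylpropyl on the amine nitrogen would respond in the same way to the added methylene. On these data alone, a longer chain, such as an ethylene link in its place, also remains open.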